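Changing a single side chain on two related cores

The compounds below may be only part of what the source reports. "The series", "measured", "known", "first", "only" and "open" are said of these compounds alone.

Three compounds share an aryl ether scaffold carrying an amide and an amino acid derived side chain, and have been tested in a functional assay on MCF7 cells (Homo sapiens) for antiproliferative activity, read by MTT assay, with a stated time of 48 h; on this read-out lower numbers stand for stronger inhibition and higher numbers for weaker inhibition. Compound 1 `Cc1nc2ccccc2nc1Oc1ccc(C(=O)N[C@@H](C)C(=O)O)cc1` gives 25600 nM. Compound 2 `CC[C@@H](C)[C@H](NC(=O)c1ccc(Oc2nc3ccccc3nc2C)cc1)C(=O)O` gives 35700 nM in this assay. Compound 3 `COC(=O)[C@H](C)NC(=O)c1ccc(Oc2nc3ccccc3nc2NC(C)(C)C)cc1` gives 38400 nM in this assay. All three numbers lie close together, and no ordering among them can be read from the data.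

The difference between compound 1 and compound 2 is sec-butyl in place of methyl on a saturated chain carbon bound to an amide-type nitrogen and a carbonyl carbon. This change produced a 1.4-fold higher number from compound 1 to compound 2 (0.14 log units; within the scatter), so the two compounds are effectively equivalent in this assay.

Compound 4 `CC[C@@H](C)[C@H](NC(=O)c1ccc(Oc2nc3ccccc3nc2NC(C)(C)C)cc1)C(=O)OC` has not yet been measured. It relates to compound 3 exactly as compound 2 relates to compound 1: the change is sec-butyl in place of methyl on a saturated chain carbon bound to an amide-type nitrogen and a carbonyl carbon, and the place at which it is made is the same in both pairs. The cores of compound 1 and compound 3 differ, but that difference is not broken down here.

Because the earlier instance of this change gave a 1.4-fold higher number from compound 1 to compound 2 (0.14 log units; within the scatter), the expected step from compound 3 to compound 4 is a 1.2-fold higher number from compound 3 to compound 4 (0.08 log units; within the scatter), a small change that stays within the usual scatter. On that basis compound 4 is estimated at 46000 nM, with a range from 20000 nM to 100000 nM expected in this assay.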

Compound 4, half-maximal inhibitory concentration: 33400 nM
For compound 4 the middle estimate is 1.4-fold (0.14 log units) above the measured one; the measured number falls inside the stated range.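

On the core of compound 3, putting sec-butyl in place of methyl on a saturated chain carbon bound to an amide-type nitrogen and a carbonyl carbon gives a 1.1-fold lower number from compound 3 to compound 4 (0.06 log units; within the scatter) in this assay. Set beside the same change on the core of compound 1, the two steps can be told apart by nothing in the data: the same change on two cores in this assay, a 1.4-fold higher number (0.14 log units; within the scatter) from compound 1 to compound 2 and a 1.1-fold lower number (0.06 log units; within the scatter) from compound 3 to compound 4, 1.6-fold (0.21 log units) apart, within the scatter of two such steps. Within the data shown here, this shows that, for these two pairs, the swap carries over from one core to the other with no step that stands out from the scatter, but it does not show that the swap has no effect at all, and two pairs say nothing firm about any further core.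

The compounds shown leave open what a group other than methyl or sec-butyl would do at this place, for example a benzyl group, a chain ending in an amine, or a longer straight chain. They also leave unresolved how the carboxylic acid of compound 1 and the methyl ester of compound 3, or the methyl and tert-butylamino groups on their cores, each bear on the read-out when taken alone.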